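This account rests on a few compounds, and the source may have more. Where it says the series, first, only, none or still open, it means among the compounds named here.

Working notes on the series. In a functional assay on HL-60 cells (Homo sapiens) for antiproliferative activity, tested at 20 uM (on this read-out higher numbers stand for a stronger effect at the one concentration tested and lower numbers for a weaker effect), compound 1 `COC(=O)c1ccc(OC)c(S(=O)(=O)Nc2ccc3c(c2)cc(C)c(=O)n3C)c1` gives 44%. Compound 2 `COc1ccc(C(=O)NOCc2ccccc2)cc1S(=O)(=O)Nc1ccc2c(c1)cc(C)c(=O)n2C` gives 13% in this assay, and compound 3 `COC(=O)c1ccc(S(=O)(=O)Nc2ccc3c(c2)cc(C)c(=O)n3C)c(OC)c1` gives 22%; the numbers of compound 2 and compound 3 lie within the scatter of each other, while compound 1 stands beyond the scatter above both. Among the measured compounds shown here, the one measured step, a number 31 percentage points lower from compound 1 to compound 2 (beyond the scatter), concerns the carbonyl substituent, not the benzyloxy ring. Compound 4 `COc1ccc(C(=O)NOCc2ccc(OC(C)=O)cc2)cc1S(=O)(=O)Nc1ccc2c(c1)cc(C)c(=O)n2C` differs from compound 2 as acetoxy in place of hydrogen on an aromatic carbon. No measured step touches the aromatic ring of the benzyloxy group, so nothing shown bears on this change directly; with the carbonyl region unchanged from compound 2, the step to compound 4 is expected to stay within the scatter, a number 3 percentage points higher from compound 2 to compound 4 (within the scatter). Compound 4 is therefore estimated at 16%, within the range 3% to 35%.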

Compound 4, a percentage reported as inhibition, at one concentration (the size of the read-out at that concentration, not a potency): 0%
Beside the measured number, compound 4's estimate is 16 percentage points above it; the whole stated range lies above it.
By their numbers in this assay, from the lowest: compound 4; then compounds 2 and 3 (each within the scatter of the next); then compound 1.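

The aromatic ring of the benzyloxy group does matter in this assay: acetoxy in place of hydrogen on this aromatic carbon, para to a large group, gives a number 13 percentage points lower from compound 2 to compound 4 (beyond the scatter), with the carbonyl region unchanged. Among the compounds shown here, the earlier step concerned only the carbonyl substituent, so this is the first sign that a change further out on the benzyloxy group also moves the number. Nothing available accounts for the fall. From the compounds shown here alone, whether it belongs to acetoxy itself or would follow any group on this carbon remains open; a hydroxyl or an amine there would help separate the two.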